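This account rests on a few compounds, and the source may have more. Where it says the series, first, only, none or still open, it means among the compounds named here.

Measured in a functional assay on Hs 683 cells (Homo sapiens) for inhibition, read by MTT assay; a higher number here means a weaker inhibitor, a lower number a stronger inhibitor:
- Compound 1 `CCCCCCCCCCCC(=O)OC1=C(CC=C(C)C)C(=O)c2ccccc2C1=O`: 18000 nM
- Compound 2 `CCCCCCCCCCCCCCCC(=O)OC1=C(CC=C(C)C)C(=O)c2ccccc2C1=O`: 48000 nM
- Compound 3 `CCCCCCCCCCCCCCCCCC(=O)OC1=C(CC=C(C)C)C(=O)c2ccccc2C1=O`: > 100000 nM

Compound 3 reads > 100000 nM, which is a limit of the assay and not a number. Its place in the series is therefore known only as the limit of > 100000 nM in this assay, at which 1 of the 3 values shown sits.

Compound 4 `CCCCCCCC/C=C\CCCCCCCC(=O)OC1=C(CC=C(C)C)C(=O)c2ccccc2C1=O` differs from compound 3 in one place: dec-1-en-1-yl in place of decyl on a saturated chain carbon, seven bonds along the chain from a carbonyl carbon. In words, dec-1-en-1-yl stands in place of decyl, which brings in one double bond outside aromatic rings.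

The measured steps all lengthen a saturated chain. They are a 2.7-fold higher number from compound 1 to compound 2 (0.43 log units; beyond the scatter), an at least 2.0-fold higher number from compound 2 to compound 3 (0.31 log units; beyond the scatter) and, across the whole series, an at least 5.5-fold higher number from compound 1 to compound 3 (0.74 log units; beyond the scatter). Each lies beyond the scatter and runs towards a higher number. None of them tests a double bond, so they bear on this change only indirectly. The change adds no length to the chain, so no further rise is expected. A modest move towards a lower number is expected instead, with compound 2 at 48000 nM as the nearest measured reference. The expected step is an at least 1.8-fold lower number from compound 3 to compound 4 (0.25 log units; that floor lies within the scatter), and this expectation is a loose one. A reading at the limit again remains possible. For compound 4 the estimated value is 55000 nM, with an expected range from 20000 nM to 100000 nM.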

Compound 4, half-maximal inhibitory concentration: 85000 nM
Compound 4: the middle estimate sits 1.5-fold (0.19 log units) below what was measured; low and high end bracket the measured number.
By their numbers in this assay, from the lowest: compound 1; then compounds 2 and 4 (each within the scatter of the next). At a limit, above all of these: compound 3.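

In this assay compound 3 gives > 100000 nM, which is a limit of the assay and not a number: the limit of > 100000 nM in this assay, at which 1 of the 4 values shown sits.

Dec-1-en-1-yl in place of decyl, seven bonds along the chain from a carbonyl carbon, keeps the count of chain carbons and brings in one double bond, and this alone gives a reading off that limit, though the size of the change can only be bounded, as an at least 1.1-fold lower number from compound 3 to compound 4 (0.07 log units; that floor lies within the scatter). The reading falls in with the shorter saturated chain, as a 1.8-fold higher number from compound 2 to compound 4 (0.25 log units; within the scatter), and not with the shortest one, as a 4.7-fold higher number from compound 1 to compound 4 (0.67 log units; beyond the scatter), so this one double bond does not bring the long chain back to the best level shown.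

Going by these compounds, the series holds a single double bond at a single place and in a single geometry, so it is open whether the trans double bond, a second double bond or the same double bond elsewhere along the chain would read the same way. On these data alone, it is also open how a chain shorter than decanoyl-length esters of this series, or an amide in place of the ester, would read on the shared core.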